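The compounds below may be only part of what the source reports. "The series", "measured", "known", "first", "only" and "open" are said of these compounds alone.

In a functional assay on BGC-823 cells (Homo sapiens) for cytotoxicity, read by CCK-8 assay, with a stated time of 72 h (on this read-out higher numbers stand for weaker inhibition and lower numbers for stronger inhibition), compound 1, whose structure is `COc1ccccc1/C=c1/[nH]c(=O)/c(=C\c2ccccc2OC)[nH]c1=O`, is recorded only as "not active" (no number reported), so no number stands against it and its place in this series cannot be fixed beyond that outcome. For the measured compounds named here, the one compound with a number is compound 2, `COc1ccccc1/C=c1\c(=O)[nH]/c(=C/c2cccc(Cl)c2Cl)c(=O)n1C`, which in this assay gives 300 nM; it differs from compound 1 in more than one place, so its result shows only what a related, substituted core can reach, not what any single change does.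

Compound 3, `C=CCn1c(=O)/c(=C\c2ccccc2OC)[nH]c(=O)/c1=C\c1ccccc1OC`, is the unmeasured compound. It differs from compound 1 by allyl in place of hydrogen on an aromatic nitrogen. Going by the values given here, no pair of measured compounds isolates this change, so the size of the step in this assay is not known from the data. Since compound 1 returned no number at all, the expectation is that compound 3 may well also give no number, or at best a weak result, with any shift in the direction of stronger inhibition remaining uncertain. Compound 3 is therefore estimated to fall at 8000 nM, in the range from 1500 nM to 40000 nM.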

Compound 3, half-maximal inhibitory concentration: 13400 nM
For compound 3 the middle estimate is 1.7-fold (0.22 log units) below the measured one; measured number inside the range.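

In this assay compound 3 gives 13400 nM while compound 1 is recorded as "not active" (no number reported) and has no number, so no step can be read between these two compounds. The size of the effect of allyl in place of hydrogen on the aromatic nitrogen stays open, and nothing shown here bears on the result.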